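From methoxy to ethoxy: free fraction in rat brain

The compounds below may be only part of what the source reports. "The series", "measured", "known", "first", "only" and "open" are said of these compounds alone.

Measured in an ADME assay on brain (Rattus norvegicus) for protein binding, read by LC-MS, using equilibrium dialysis, with a stated time of 6 h; on this read-out higher numbers stand for a larger free fraction and lower numbers for a smaller free fraction:
- compound 1 `COc1cc(C(=O)Nc2cc(OC(F)(F)F)ccc2-n2cncn2)ccc1OC1CC1`: 0.013
- compound 2 `COc1ccc(C(=O)Nc2cc(OC(F)(F)F)ccc2-n2cncn2)cc1OC`: 0.034

Of these two, compound 2 has the higher number, at 0.034, and so the larger free fraction. The next compound to be measured is compound 3 `CCOc1ccc(C(=O)Nc2cc(OC(F)(F)F)ccc2-n2cncn2)cc1OC`. Its difference from compound 2 is methyl in place of hydrogen on a saturated chain carbon bound to an oxygen on an aromatic ring. In words, this is methyl in place of hydrogen on a saturated chain carbon bound to an oxygen on an aromatic ring, which turns methoxy into ethoxy.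

Among the measured compounds shown here, only one measured step bears on this change: a 2.6-fold higher number from compound 1 to compound 2 (0.42 log units; beyond the scatter). There, methyl took the place of cyclopropyl on an oxygen on an aromatic ring, and the step was modest but beyond the scatter. Ethoxy has not yet been measured in this assay, so that single step is a weak guide. Going back from methyl towards a larger group may undo part of it, so a smaller move to a lower number is expected. The expected change is a 1.5-fold lower number from compound 2 to compound 3 (0.19 log units; within the scatter), which would not clearly exceed the scatter. For compound 3 the estimated value is 0.022, with an expected range of 0.012 to 0.038.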

Compound 3, unbound fraction: 0.017
The estimate for compound 3 lay 1.3-fold (0.11 log units) above the measured number, and the stated range covers the measured number.
By their numbers in this assay, from the lowest: compounds 1, 3 and 2 (each within the scatter of the next, the first and the last beyond it).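

In this assay, turning methoxy into ethoxy on the shared core gives a 2.0-fold lower number from compound 2 to compound 3 (0.30 log units; within the scatter), so a single added methyl on the saturated chain carbon bound to an oxygen on an aromatic ring does not yet separate from the scatter. Exchanging cyclopropyl for ethyl on the same oxygen gives a 1.3-fold higher number from compound 1 to compound 3 (0.12 log units; within the scatter), which also stays within the scatter, although the methyl and cyclopropyl ethers are set apart by a 2.6-fold higher number from compound 1 to compound 2 (0.42 log units; beyond the scatter), a step beyond it. Ethoxy therefore cannot be assigned to either side of that earlier gap, and the clear separation seen so far holds only between compound 1 and compound 2, while no measurement given here explains the numbers at this position.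

From the compounds shown here alone, what remains open is whether a longer chain such as propoxy, or a chain bearing an amine or a carboxylic acid, would move the free fraction clearly beyond the scatter at this oxygen. Also unresolved is whether a change to the other methoxy group would give a step of similar size in this assay.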